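Replacing the 3-chlorothiophen-2-yl group of compound 2

The source may hold more compounds than are shown below. What is called first, only, known or untested is meant among the compounds shown, and "the series" means these compounds.

In a functional assay on HUVEC cells (Homo sapiens), read by BrdU incorporation, with a stated time of 72 h (a lower number here means a stronger inhibitor, a higher number a weaker inhibitor), compound 1 (`Cc1ccc2nc(Cl)c(/C=C/C(=O)c3sccc3C)cc2c1`) gives 127 nM while compound 2 (`Cc1ccc2nc(Cl)c(/C=C/C(=O)c3sccc3Cl)cc2c1`) gives 37.5 nM and so holds the lower of the two numbers. Compound 3 (`Cc1ccc2nc(Cl)c(/C=C/C(=O)c3cc(C)sc3C)cc2c1`) has 2,5-dimethylthiophen-3-yl in place of 3-chlorothiophen-2-yl on a carbonyl carbon and keeps the shared core. For the measured compounds named here, one measured step bears on this change: a 3.4-fold lower number from compound 1 to compound 2 (0.53 log units; beyond the scatter) with chloro in place of methyl on an aromatic carbon, a modest step beyond the scatter. Compound 3 has no chloro group and carries methyl groups, so a step of similar size in the opposite direction is expected. Going by the values given here, no measured compound carries its 2,5-dimethylthiophen-3-yl group, which leaves the expectation loose. The estimated change is a 3.2-fold higher number from compound 2 to compound 3 (0.51 log units; beyond the scatter) in this assay toward a weaker inhibitor. Compound 3 is expected at about 120 nM with an estimated range of 35 nM to 400 nM in this measurement.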

Compound 3, half-maximal inhibitory concentration: 229 nM
For compound 3 the middle estimate is 1.9-fold (0.28 log units) below the measured one; measured number inside the range.
By their numbers in this assay, from the lowest: compound 2; then compounds 1 and 3 (each within the scatter of the next).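

In this assay the change to 2,5-dimethylthiophen-3-yl on the carbonyl carbon gives a 6.1-fold higher number from compound 2 to compound 3 (0.79 log units; beyond the scatter), a larger step than the earlier chloro for methyl exchange had shown. Set against the methyl-bearing group instead, the same 2,5-dimethylthiophen-3-yl group gives a 1.8-fold higher number from compound 1 to compound 3 (0.26 log units; within the scatter), so these two chlorine-free thiophene groups cannot be told apart here, even though they differ in their methyl groups and in how the ring is attached, and among the three compounds only the 3-chlorothiophen-2-yl group of compound 2 stands apart. Nothing shown accounts for this separation. The compounds leave open whether the lower number of compound 2 depends on the chloro group itself or on the 3-chlorothiophen-2-yl group as a whole. On these data alone, how a bromo-substituted thiophene or a phenyl ring would read on the same carbonyl carbon also remains open.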